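The source may report more compounds than this note shows. Statements on the series, on what has been measured and on what is new or still open speak of the compounds shown alone.

The series rests on a shared core carrying a nitrile and an amide, and two members of it have so far been measured. Compound 1, `N#C/C(=C\c1cccc(Br)n1)C(=O)N[C@@H]1CCCc2ccccc21`, and compound 2, `N#C/C(=C\c1cccc(Br)n1)C(=O)N[C@@H](CO)c1ccccc1`, were both tested in a functional assay on MM1 cells (Homo sapiens) for antiproliferative activity, read by MTT assay, with a stated time of 72 h; a higher number here means a weaker inhibitor, a lower number a stronger inhibitor. In this assay compound 1 gives 1500 nM, and compound 2 gives 2800 nM. Compound 2 thus carries the highest of the two numbers recorded, but its nearest neighbour is compound 1, and the gap between these two values lies within the scatter of repeated measurements, so the two compounds cannot be ranked against each other on this evidence.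

The next member, compound 3, `CC[C@H](NC(=O)/C(C#N)=C/c1cccc(Br)n1)c1ccccc1`, has not yet been measured. It differs from compound 2 in one place: methyl in place of hydroxy on a saturated chain carbon, two bonds along the chain from an amide-type nitrogen and an aromatic carbon, or, cut one bond further out, hydroxymethyl to ethyl. Among the measured compounds shown here, no step between measured compounds covers this kind of change, so nothing in the measured pairs tells how large its effect should be. For the measured compounds named here, what the two measured values show is only that a neighbour lacking the hydroxy group, compound 1, sits at 1500 nM, close to compound 2. On that basis compound 3 is expected to land near compound 2, with a step of a 1.4-fold lower number from compound 2 to compound 3 (0.15 log units; within the scatter) that stays within the scatter. The estimate for compound 3 in this assay is 2000 nM, with a range from 800 nM to 5000 nM.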

Compound 3, half-maximal inhibitory concentration: 1100 nM
The estimate for compound 3 lay 1.8-fold (0.26 log units) above the measured number; the measured number falls inside the stated range.
By their numbers in this assay, from the lowest: compounds 3, 1 and 2 (each within the scatter of the next, the first and the last beyond it).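

On the saturated chain carbon, two bonds along the chain from an amide-type nitrogen and an aromatic carbon, the change from hydroxymethyl to ethyl now has a measured size in this assay: a 2.5-fold lower number from compound 2 to compound 3 (0.41 log units; beyond the scatter), a modest step that lies beyond the usual scatter. Among the compounds shown here, it is the only step between measured compounds, and so gives the first direct sign that this position responds to a change of group, with the lower number on the side of the ethyl compound, which carries neither the hydrogen-bond donor nor the hydrogen-bond acceptor of the hydroxy group. No measurement at hand gives a reason for the size or the direction of this step.

The compounds shown leave open how far this trend extends along the chain, since one single step cannot tell whether a longer chain such as propyl would continue it, or whether an amine or a carboxylic acid at the same place would reverse it. They also leave open whether methyl in place of hydroxy would give a step of similar size on a different amide substituent of the shared core.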